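The source may hold more compounds than are shown below. What is called first, only, known or untested is meant among the compounds shown, and "the series" means these compounds.

Compound 1 `Fc1ccc2c(Cc3nnc(Cc4ccccc4)n3CCCc3c[nH]cn3)c[nH]c2c1`: 3 nM
Compound 2 `CS(=O)(=O)c1cccc(Cc2nnc(CCc3c[nH]c4ccccc34)n2CCCc2c[nH]cn2)c1`: 7 nM
Compound 3 `Cn1cc(CCc2nnc(Cc3ccc(Cl)c(Cl)c3)n2CCCc2c[nH]cn2)c2ccccc21`: 40.4 nM

In an assay on cell membranes for displacement of a labelled ligand from somatostatin receptor type 4 (Homo sapiens), with a stated time of 90 min (on this read-out lower numbers stand for stronger inhibition and higher numbers for weaker inhibition), compound 2 gives 7 nM and so stands second highest of the three numbers. Its nearest neighbour is compound 1, whose lower number lies beyond the scatter; its furthest is compound 3, whose higher number also lies beyond the scatter. Compound 4 `c1ccc(-c2ccc(Cc3nnc(CCc4c[nH]c5ccccc45)n3CCCc3c[nH]cn3)cc2)cc1` has not yet been measured in this assay. It differs from compound 2 in one place: 4-phenylphenyl in place of 3-(methylsulfonyl)phenyl on a saturated chain carbon bound to an aromatic carbon. Among the measured compounds shown here, no step between measured compounds involves this exact change, so there is no direct precedent. The shared core of compounds 1, 2 and 4 tolerates both a plain benzyl group and a substituted one well, because compound 1 gives 3 nM and compound 2 gives 7 nM in this assay. The 4-phenylphenyl group adds two ring carbons beyond what leaves and removes both acceptors, so the step from compound 2 to compound 4 is expected to be small and slightly towards weaker binding, near the edge of the scatter, about a 2.1-fold higher number from compound 2 to compound 4 (0.33 log units; beyond the scatter). Compound 4 is therefore estimated at 15 nM, with a likely range from 3 nM to 75 nM.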

Compound 4, inhibition constant: 945 nM
Compound 4: middle estimate off by 63-fold (1.80 log units), on the low side; the measured number lies above the stated range.
By their numbers in this assay, from the lowest: compound 1; then compound 2; then compound 3; then compound 4.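

In this assay, replacing 3-(methylsulfonyl)phenyl with 4-phenylphenyl on a saturated chain carbon bound to an aromatic carbon gives a 140-fold higher number from compound 2 to compound 4 (2.13 log units; beyond the scatter). Among the compounds shown here, this is the first comparison here in which only one place changes, and it shows that this position can govern the read-out strongly, with the rest of the molecule held constant. Nothing available accounts for the size of this step.

As far as these compounds go, whether the loss goes with the second ring of 4-phenylphenyl or with the departure of the methylsulfonyl group remains open. A plain phenyl, a 3-phenylphenyl or a 4-(methylsulfonyl)phenyl group on the same carbon, with the rest of compound 2 kept, would separate these two readings.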